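Aryl groups replacing methoxy: microsomal clearance in the series

The source may report more compounds than this note shows. Statements on the series, on what has been measured and on what is new or still open speak of the compounds shown alone.

compound 1 `COc1cc(C(O)(C(F)(F)F)C(F)(F)F)cnc1N1CCN(S(=O)(=O)c2ccc(N)nc2)CC1` gives < 14 mL.min-1.g-1 in an ADME assay (liver) for metabolic stability, with Liver microsome (Homo sapiens) as the target, using microsomes and NADPH, with a stated time of 30 min, tested at 1 uM; a lower number here means slower removal, a higher number faster removal of the compound.
compound 2 `CCn1cc(-c2cc(C(O)(C(F)(F)F)C(F)(F)F)cnc2N2CCN(S(=O)(=O)c3ccc(N)nc3)CC2)cn1` gives 20 mL.min-1.g-1 in this assay.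
compound 3 `Cc1ccc(-c2cc(C(O)(C(F)(F)F)C(F)(F)F)cnc2N2CCN(S(=O)(=O)c3ccc(N)nc3)CC2)cn1` gives 43 mL.min-1.g-1 in this assay.

Compound 1 stands only at a limit of this assay, namely (the limit of < 14 mL.min-1.g-1 in this assay, at which 1 of the 3 values shown sits). Both measured steps leave that limit toward a number: an at least 1.4-fold higher number from compound 1 to compound 2 (0.15 log units; that floor lies within the scatter), and an at least 3.0-fold higher number from compound 1 to compound 3 (0.48 log units; beyond the scatter). Between the two aryl analogues the step is a 2.2-fold higher number from compound 2 to compound 3 (0.33 log units; beyond the scatter).

Compound 4 `COc1cncc(-c2cc(C(O)(C(F)(F)F)C(F)(F)F)cnc2N2CCN(S(=O)(=O)c3ccc(N)nc3)CC2)c1` differs from compound 1 by 5-methoxypyridin-3-yl in place of methoxy on an aromatic carbon. The two steps from compound 1 bear on this change, both pointing to a higher number, with the six-membered aryl of compound 3 giving the larger step. A step upward of at least modest size is therefore expected, an at least 2.5-fold higher number from compound 1 to compound 4 (0.39 log units; beyond the scatter). Compound 4 is estimated at 35 mL.min-1.g-1, with a range from 15 mL.min-1.g-1 to 80 mL.min-1.g-1.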

Compound 4, intrinsic clearance in microsomes: 44 mL.min-1.g-1
Estimate against measurement, compound 4: 1.3-fold (0.10 log units) below; the measured number falls inside the stated range.
By their numbers in this assay, from the lowest: compound 2; then compounds 3 and 4 (each within the scatter of the next). At a limit, below all of these: compound 1.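

On this aromatic carbon, the methoxy carried on the added ring in 5-methoxypyridin-3-yl reads the same as the methyl of 6-methylpyridin-3-yl in this assay, with a 1.0-fold higher number from compound 3 to compound 4 (0.01 log units; within the scatter) between them. Compounds 3 and 4 both stand apart from the pyrazole of compound 2, with a 2.2-fold higher number from compound 2 to compound 4 (0.34 log units; beyond the scatter) for the newer pyridine. Compound 1 stands at a limit, not a number, so an at least 3.1-fold higher number from compound 1 to compound 4 (0.49 log units; beyond the scatter) gives only a floor for this change: the limit of < 14 mL.min-1.g-1 in this assay, at which 1 of the 4 values shown sits.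

Open, on these data alone, is whether an amine or a carboxylic acid on the added pyridine ring would bring the number back toward compound 1. Also open, as far as these compounds go, is how a saturated ring such as morpholine would read on this carbon.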